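Tail replacement in the oxazole ketone series

The source may hold more compounds than are shown below. What is called first, only, known or untested is meant among the compounds shown, and "the series" means these compounds.

Compound 1 `O=C(CCCCCCc1ccccc1C(=O)O)c1ncc(-c2ccccn2)o1` carries a 2-carboxyphenyl tail. In an assay for inhibition of Fatty-acid amide hydrolase 1 (Rattus norvegicus) (a lower number here means a stronger inhibitor, a higher number a weaker inhibitor), compound 1 gives > 600 nM, which is a limit of the assay and not a number. Compound 2 `O=C(CCCCCCc1cccc(Cl)c1Cl)c1ncc(-c2ccccn2)o1` gives 0.9 nM in this assay; the step of an at least 660-fold lower number from compound 1 to compound 2 (2.82 log units; beyond the scatter) is the only measured step, and compound 2 holds the only number shown, the other value shown being (the limit of > 600 nM in this assay, at which 1 of the 2 values shown sits). Compound 3 `CN(CCCCCC(=O)c1ncc(-c2ccccn2)o1)c1ccccc1` differs from compound 2 by methyl(phenyl)amino in place of 2,3-dichlorobenzyl on a saturated chain carbon, five bonds along the chain from a carbonyl carbon. Among the compounds with values here, the one measured step shows the tail can move this assay strongly; compound 3 again alters the tail and gives up the 2,3-dichlorophenyl, so a weakening step a 22-fold higher number from compound 2 to compound 3 (1.35 log units; beyond the scatter) is expected. Compound 3 is estimated at 20 nM, in the range 2 nM to 200 nM.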

Compound 3, inhibition constant: 40 nM
Estimate against measurement, compound 3: 2.0-fold (0.30 log units) below, within the range that was stated.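

In this assay, putting methyl(phenyl)amino in place of 2,3-dichlorobenzyl at this place gives a 44-fold higher number from compound 2 to compound 3 (1.65 log units; beyond the scatter). The position therefore accepts a tail with a nitrogen and no chlorine and still gives a measured number, with compound 3 at 40 nM, but the change costs much of the potency of compound 2. Nothing shown accounts for the size of this step.

Open, from the compounds shown here alone, is whether the loss follows the added nitrogen or the lost chlorines: an unsubstituted benzyl tail would separate the two. Going by these compounds, the effect of a longer chain on the methyl(phenyl)amino tail also stays open.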